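A few compounds are considered here, and "the series" means these few. Any claim that something is new, unique, unknown or untested is made for them only; others in the source may bear on it.

Three compounds have been measured in a functional assay on isolated protein for antagonist activity at adenosine receptor A2b (Homo sapiens); a lower number here means a stronger inhibitor, a higher number a weaker inhibitor:

compound 1, `CC(=O)Oc1ccc2cc(-c3ccsc3)c(=O)oc2c1OC(C)=O`, gives > 30000 nM, which is a limit of the assay and not a number.
compound 2, `CC(=O)Oc1ccc2cc(-c3cc(Br)cs3)c(=O)oc2c1OC(C)=O`, gives > 30000 nM, again a limit rather than a number.
compound 3, `O=c1oc2c(O)cccc2cc1-c1ccsc1`, gives > 30000 nM, also a limit rather than a number.

Compound 2 arises from compound 1 by one change, (4-bromothiophen-2-yl in place of thiophen-3-yl on an aromatic carbon). The step this made, a step that the two limits leave unreadable from compound 1 to compound 2, cannot be read, because the limit of > 30000 nM in this assay, at which 3 of the 3 values shown sit, holds both values. The core of compound 3 differs from the core of compound 1, but that difference is not broken down here.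

Compound 4, `O=c1oc2c(O)cccc2cc1-c1cc(Br)cs1`, is not yet measured. It arises from compound 3 by 4-bromothiophen-2-yl in place of thiophen-3-yl on an aromatic carbon, with the place described in the same words as for compound 1 and compound 2, so it is the same change. In this assay the step from compound 3 to compound 4 is expected to be a number no higher from compound 3 to compound 4 (the limit leaves the size open), an expectation that rests on compound 3, whose value sits at the limit of > 30000 nM in this assay, at which 3 of the 3 values shown sit, and on compound 1 and compound 2, whose values sit there too. Compound 4 is therefore estimated at 30000 nM, most likely again reported only as a limit, within a range of 10000 nM to 100000 nM.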

Compound 4, inhibition constant: > 30000 nM
Compound 4 was reported as a limit; the forecaster's own chance of this, stated with the estimate: 85%; the middle value lies on the limit itself.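

In this assay compound 4 gives > 30000 nM and this is a limit of the assay, not a number. The step from compound 3 to compound 4 cannot be read, because both values sit at the same limit: the limit of > 30000 nM in this assay, at which 4 of the 4 values shown sit.

The compounds shown leave open whether 4-bromothiophen-2-yl in place of thiophen-3-yl changes activity at all, and how far each compound lies beyond that limit.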